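This account rests on a few compounds, and the source may have more. Where it says the series, first, only, none or still open, it means among the compounds named here.

In an ADME assay on NIH3T3 cells (Mus musculus) for cytotoxicity, read by MTT assay, with a stated time of 48 h (a lower number here means that less compound is tolerated, a higher number that more compound is tolerated), compound 3 (`COc1ccc(/C=C/C(=O)c2ccc(OC)c(S(=O)(=O)Nc3c(N)nc(SC)[nH]c3=O)c2)cc1`) gives 6500 nM and stands level, within the scatter, with compound 2 (`COc1ccc(C(=O)/C=C/c2ccc(C)cc2)cc1S(=O)(=O)Nc1c(N)nc(SC)[nH]c1=O`) at 7200 nM on the same read-out. Compound 1 (`COc1ccc(C(=O)/C=C/c2cc(OC)c(OC)c(OC)c2)cc1S(N)(=O)=O`) gives a clearly lower number than either of them (2400 nM). Compound 4 (`COc1ccc(C(=O)/C=C/c2cc(OC)c(OC)c(OC)c2)cc1S(=O)(=O)Nc1c(N)nc(SC)[nH]c1=O`) differs from compound 3 by 3,4,5-trimethoxyphenyl in place of 4-methoxyphenyl on a double-bonded chain carbon bound to a double-bonded chain carbon. Among the measured compounds shown here, no measured step makes this exchange. For the measured compounds named here, the only step available (a 1.1-fold lower number from compound 2 to compound 3 (0.04 log units; within the scatter)) puts methoxy in place of methyl on an aromatic carbon, and it gives no sign of a large move. Compound 1 (2400 nM) also carries the 3,4,5-trimethoxyphenyl group, but its sulfonamide is unsubstituted, so it offers only a weak hint of a downward move. A small downward step is therefore expected, estimated as a 1.4-fold lower number from compound 3 to compound 4 (0.13 log units; within the scatter) in this assay for this change. Compound 4 is expected at 4800 nM (estimated range 2200 nM to 9500 nM).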

Compound 4, concentration lethal to 50% of the cells: 2100 nM
For compound 4 the middle estimate is 2.3-fold (0.36 log units) above the measured one, outside the stated range (below it).
By their numbers in this assay, from the lowest: compounds 4 and 1 (each within the scatter of the next); then compounds 3 and 2 (each within the scatter of the next).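

In this assay, the exchange at this chain position proves able to move the number beyond the scatter, with 3,4,5-trimethoxyphenyl in place of 4-methoxyphenyl giving a 3.1-fold lower number from compound 3 to compound 4 (0.49 log units; beyond the scatter) and in place of 4-methylphenyl giving a 3.4-fold lower number from compound 2 to compound 4 (0.54 log units; beyond the scatter), whereas methoxy in place of methyl on the aromatic carbon had left the number level. With 3,4,5-trimethoxyphenyl on the chain, the group of 10 heavy atoms on the sulfonamide nitrogen leaves the number level, at a 1.1-fold lower number from compound 1 to compound 4 (0.06 log units; within the scatter), so the unsubstituted sulfonamide was a closer guide than it first appeared. Nothing available gives a reason for this move. The compounds shown leave open whether the sulfonamide nitrogen exchange would also stay level with 4-methoxyphenyl on the chain. They also leave open how a group carrying an amine or a carboxylic acid would stand at this chain position.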